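A few compounds are considered here, and "the series" means these few. Any claim that something is new, unique, unknown or untested is made for them only; others in the source may bear on it.

Measured compounds:
Compound 1 `COC(=O)c1ccccc1OCc1cn(-c2ccc(S(=O)(=O)N3CCc4ccccc4C3)cc2)nn1` in a functional assay on MOLT-3 cells (Homo sapiens) for cytotoxicity, read by MTT assay, with a stated time of 48 h (on this read-out lower numbers stand for stronger inhibition and higher numbers for weaker inhibition), gives 18600 nM.
Compound 2 `O=c1cc(OCc2cn(-c3ccc(S(=O)(=O)N4CCc5ccccc5C4)cc3)nn2)c2ccccc2o1` gives 80800 nM.
Compound 3 `COc1cc2c(cc1OC)CN(S(=O)(=O)c1ccc(-n3cc(COc4ccc5ccccc5c4)nn3)cc1)CC2` gives 36400 nM.

Compound 3 and compound 1 lie within the scatter of each other, while compound 2 sits higher, beyond the scatter. Compound 4 `COc1cc2c(cc1OC)CN(S(=O)(=O)c1ccc(-n3cc(COc4ccc(C=O)cc4OC)nn3)cc1)CC2` arises from compound 3 by 4-formyl-2-methoxyphenyl in place of naphthalen-2-yl on an oxygen on a saturated carbon. Going by the values given here, only one measured step touches this same position, a 4.3-fold higher number from compound 1 to compound 2 (0.64 log units; beyond the scatter), and it was modest. Compound 1, which also carries one six-membered aromatic ring of carbon only on that oxygen, gives a number within the scatter of compound 3. The expected step is therefore small, a 1.7-fold lower number from compound 3 to compound 4 (0.22 log units; within the scatter), leaning if anything toward the number of compound 1. Compound 4 is estimated at 22000 nM, with a range from 9000 nM to 55000 nM.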

Compound 4, half-maximal inhibitory concentration: 5500 nM
For compound 4 the middle estimate is 4.0-fold (0.60 log units) above the measured one; the whole stated range lies above it.
By their numbers in this assay, from the lowest: compound 4; then compounds 1 and 3 (each within the scatter of the next); then compound 2.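

In this assay, going by these compounds alone, the group on this oxygen can lower the number as well as raise it: the one earlier step here was a 4.3-fold higher number from compound 1 to compound 2 (0.64 log units; beyond the scatter), whereas this one is a 6.6-fold lower number from compound 3 to compound 4 (0.82 log units; beyond the scatter). Both groups in this change count 10 heavy atoms, so the shift comes with that count unchanged, while one aromatic ring replaces two and two hydrogen-bond acceptors enter. No measurement available here explains the shift. The compounds shown leave open whether the formyl or the methoxy carries the step, and what a carboxylic acid in place of the formyl would give.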